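Chlorophenyl placement on the shared core

The source may hold more compounds than are shown below. What is called first, only, known or untested is meant among the compounds shown, and "the series" means these compounds.

Compound 2 `O=c1c2ccccc2[se]n1-c1nnc(-c2ccc(Cl)cc2)s1` carries a 4-chlorophenyl on the shared core; in a functional assay on SSMC-7721 cells (Homo sapiens) for antiproliferative activity, read by CCK-8 assay, with a stated time of 48 h (a lower number here means a stronger inhibitor, a higher number a weaker inhibitor), compound 2 gives 24400 nM. Among the three measured compounds it stands second highest: nearest is compound 1 `O=c1c2ccccc2[se]n1-c1nnc(-c2cccc([N+](=O)[O-])c2)s1`, which gives 27300 nM, and furthest is compound 3 `COc1ccc(-c2nnc(-n3[se]c4ccccc4c3=O)s2)cc1`, which gives 16500 nM; both gaps lie within the scatter. Within the data shown here, the only single-point step so far, a 1.5-fold lower number from compound 2 to compound 3 (0.17 log units; within the scatter), swaps a ring substituent and does not move the number beyond the scatter.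

Compound 4 `O=c1c2ccccc2[se]n1-c1nnc(-c2ccccc2Cl)s1` differs from compound 2 by 2-chlorophenyl in place of 4-chlorophenyl on an aromatic carbon. Among the measured compounds shown here, no measured step moves the chlorine around the phenyl ring, so nothing bears directly on this change; the one step available, a 1.5-fold lower number from compound 2 to compound 3 (0.17 log units; within the scatter), only shows that a change on that ring left the number within the scatter. The expectation is therefore no step beyond the scatter, that is a 1.0-fold lower number from compound 2 to compound 4 (0.01 log units; within the scatter) in this assay. For compound 4 the estimated value is 24000 nM, with a range from 10000 nM to 60000 nM.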

Compound 4, half-maximal inhibitory concentration: 40200 nM
Compound 4: the middle estimate sits 1.7-fold (0.22 log units) below what was measured, and the stated range covers the measured number.
By their numbers in this assay, from the lowest: compounds 3, 2, 1 and 4 (each within the scatter of the next, the first and the last beyond it).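

Moving the chlorine gives the first measured step that concerns where a substituent sits on the phenyl ring rather than which substituent it is. In this assay the exchange of 4-chlorophenyl for 2-chlorophenyl gives a 1.6-fold higher number from compound 2 to compound 4 (0.22 log units; within the scatter) and so stays within the scatter, which means the two chlorine placements cannot be told apart and neither ranks above the other. No measurement is available that bears on a reason for this result.

On these data alone, whether the same move would stay within the scatter for a substituent other than chlorine remains open, since methoxy and nitro each appear at a single placement. Also open, as far as these compounds go, is whether an amine or a carboxylic acid on the phenyl ring would give a step beyond the scatter from compound 2.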